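Cyclohexyl for Butyl on the Piperazine Amide

A few compounds are considered here, and "the series" means these few. Any claim that something is new, unique, unknown or untested is made for them only; others in the source may bear on it.

Three compounds sharing a core were tested in a functional assay on MCF7 cells (Homo sapiens) for inhibition, read by MTT assay, with a stated time of 72 h; on this read-out higher numbers stand for weaker inhibition and lower numbers for stronger inhibition. Compound 1 `OCCNc1nnc2nncn2n1` gives 11600 nM. Compound 2 `OCC(CO)(CO)Nc1nnc2nncn2n1` reaches only the limit of the assay, > 100000 nM, so its value is a limit and not a number (the limit of > 100000 nM in this assay, at which 1 of the 3 values shown sits). Compound 3 `CCCCC(=O)N1CCN(c2nnc3nncn3n2)CC1` gives 2760 nM, the lowest of the two numbers obtained; the nearest number is that of compound 1, and the gap between them lies beyond the usual scatter.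

Compound 4 `O=C(C1CCCCC1)N1CCN(c2nnc3nncn3n2)CC1` has not yet been measured in this assay. It differs from compound 3 in a single place cyclohexyl in place of butyl on a carbonyl carbon: a cyclohexyl group in place of a butyl group on the carbonyl carbon. Among the compounds with values here, no pair of measured compounds shows what such an exchange does here, so the expectation rests on compound 3 alone, whose value of 2760 nM is taken as the starting point.

The step from compound 3 to compound 4 is expected to be small, a 1.4-fold lower number from compound 3 to compound 4 (0.14 log units; within the scatter), leaning toward slightly stronger inhibition but not clearly beyond the scatter. Compound 4 is therefore estimated at 2000 nM, with a range from 600 nM to 7000 nM.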

Compound 4, half-maximal inhibitory concentration: 1260 nM
Estimate against measurement, compound 4: 1.6-fold (0.20 log units) above; the measured number falls inside the stated range.
By their numbers in this assay, from the lowest: compound 4; then compound 3; then compound 1. At a limit, above all of these: compound 2.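

In this assay, within the data shown here, the carbonyl carbon of the shared core gives the first readable single exchange of the series: cyclohexyl in place of butyl produces a 2.2-fold lower number from compound 3 to compound 4 (0.34 log units; beyond the scatter), a modest step. The earlier compounds shown here differed from one another in more than one place, so they could not show what one change at this position does; this pair shows that a six-membered ring of carbon only is accepted here in place of an open butyl chain, and that the number moves down rather than up. Because it rests on one pair, the result sets a direction for this single exchange and no trend across the series, and compound 1 and compound 2 add nothing to it.

As far as these compounds go, whether the number would keep falling with a phenyl ring, a longer chain such as octyl, or a smaller ring such as cyclopropyl on the same carbonyl carbon remains open, as does the effect of an amine or a carboxylic acid on the cyclohexyl ring. Nothing among the values shown gives a cause for this step.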